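A few compounds are considered here, and "the series" means these few. Any claim that something is new, unique, unknown or untested is made for them only; others in the source may bear on it.

Compound 1 `Fc1ccc(C2(c3ccc(F)cc3)CNC(c3ccccc3)=N2)cc1` gives 32 nM in an assay on LM cells for displacement of a labelled ligand from Neuropeptide Y receptor type 5 (Homo sapiens); on this read-out lower numbers stand for stronger inhibition and higher numbers for weaker inhibition. Compound 2 `Fc1ccc(C2(c3ccc(F)cc3)CNC(c3ccc(C(F)(F)F)cc3)=N2)cc1` gives 160 nM. Compound 3 `Fc1ccc(C2(c3ccc(F)cc3)CNC(c3cccc(F)c3)=N2)cc1` gives 10 nM.

Among these three, compound 3 has the lowest number in this assay. Its nearest neighbour is compound 1, separated by the step of a 3.2-fold lower number from compound 1 to compound 3 (0.51 log units; beyond the scatter), and compound 2 lies furthest away, the step of a 5.0-fold higher number from compound 1 to compound 2 (0.70 log units; beyond the scatter) having carried compound 2 off in the opposite direction from compound 1.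

Compound 4 `Cc1cccc(C2=NC(c3ccc(F)cc3)(c3ccc(F)cc3)CN2)c1` differs from compound 3 in one place: methyl in place of fluoro on an aromatic carbon. Among the compounds with values here, no measured step swaps fluoro for methyl, so the two steps that touch the same ring are the only guide. Fluoro entering that ring gave a 3.2-fold lower number from compound 1 to compound 3 (0.51 log units; beyond the scatter), while trifluoromethyl entering it gave a 5.0-fold higher number from compound 1 to compound 2 (0.70 log units; beyond the scatter); a methyl sits between these two substituents in kind, and a step of intermediate size, if any, is the reasonable reading. The expected step from compound 3 to compound 4 in this assay is therefore a 2.0-fold higher number from compound 3 to compound 4 (0.30 log units; within the scatter), a modest rise that may not clear the scatter. For compound 4 the estimate in this assay is 20 nM, with a range from 7 nM to 60 nM.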

Compound 4, half-maximal inhibitory concentration: 30 nM
For compound 4 the middle estimate is 1.5-fold (0.18 log units) below the measured one, and the stated range covers the measured number.
By their numbers in this assay, from the lowest: compound 3; then compounds 4 and 1 (each within the scatter of the next); then compound 2.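

Within this assay, the result shows that fluoro and methyl are not interchangeable at this place, a carbon of the six-membered aromatic ring meta to a large group: the swap gives a 3.0-fold higher number from compound 3 to compound 4 (0.48 log units; beyond the scatter) and so loses what fluoro had gained. Methyl in place of the hydrogen of compound 1 gives a 1.1-fold lower number from compound 1 to compound 4 (0.03 log units; within the scatter) and so leaves the two compounds indistinguishable, which means that a small substituent at this carbon does not by itself lower the number, and of the two groups seen here only fluoro does. Nothing available explains why fluoro and methyl part in this way.

The compounds shown leave open whether the lower number is peculiar to fluoro or would also come with chloro, methoxy or an amine on the same carbon, and whether a longer chain such as ethyl would stay level with methyl or rise towards the higher numbers. They also leave open how 3-fluorophenyl compares with the same fluoro on another carbon of that ring, so the importance of the place itself, as distinct from the group, is still unsettled.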